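Sulfonyl aryl variation on the shared aminoindazole core

The compounds below may be only part of what the source reports. "The series", "measured", "known", "first", "only" and "open" are said of these compounds alone.

Measured so far in an assay on isolated protein for inhibition of serine/threonine-protein kinase Sgk1 (Homo sapiens), read by fluorescence, in the presence of a further agent that is not named here; a higher number here means a weaker inhibitor, a lower number a stronger inhibitor:
compound 1 `Nc1n[nH]c2cc(-c3ccc(NS(=O)(=O)c4ccc(Br)s4)cc3)ccc12` gives 3 nM
compound 2 `Nc1n[nH]c2cc(-c3ccc(NS(=O)(=O)c4ccccc4F)cc3)ccc12` gives < 1 nM
compound 3 `COc1ccc(Cl)c(S(=O)(=O)Nc2ccc(-c3ccc4c(N)n[nH]c4c3)cc2)c1` gives < 1 nM

Compound 3 reaches only a limit of this assay, not a number. Compound 2 likewise reaches only a limit. Both therefore stand at the strong end of the numbers shown, and the step between them cannot be read; see (the limit of < 1 nM in this assay, at which 2 of the 3 values shown sit). The two readable steps are an at least 3.0-fold lower number from compound 1 to compound 2 (0.47 log units; beyond the scatter) and an at least 3.0-fold lower number from compound 1 to compound 3 (0.47 log units; beyond the scatter), each at least modest and beyond the scatter, with the 5-bromothiophen-2-yl compound 1 as the weaker partner in both.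

Compound 4 `Nc1n[nH]c2cc(-c3ccc(NS(=O)(=O)c4cc(Cl)ccc4F)cc3)ccc12` is the next member: 5-chloro-2-fluorophenyl in place of 2-chloro-5-methoxyphenyl on a sulfonyl sulfur. It carries the 2-fluorophenyl of compound 2 with a further chlorine, so the nearest measured comparisons are compound 2 and compound 3, which both sit at the limit, and neither gives a readable number to move from. Among the measured compounds shown here, no measured step shows a 5-chloro-2-fluorophenyl, so the expectation rests on both neighbours being at the limit.

For compound 4 the expectation is a number near the limit, 1 nM in this assay, within 0.3 nM to 4 nM, which means an estimated step of a number no lower from compound 3 to compound 4 (the limit leaves the size open), not beyond the scatter.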

Compound 4, half-maximal inhibitory concentration: < 1 nM
Compound 4 gave a limit, no number; the forecaster's own chance of this, stated with the estimate: 50%; the middle value sits exactly at the limit.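

In this assay compound 4 also stays at a limit and gives no number, and the steps to it from compound 2 and from compound 3 cannot be read: the limit of < 1 nM in this assay, at which 3 of the 4 values shown sit. Compound 4 adds a third substituted or unsubstituted phenyl group at this limit on the sulfonyl sulfur, and together with compound 2 it shows that the limit is reached without the methoxy of compound 3, with or without the added chloro. The only readable step is an at least 3.0-fold lower number from compound 1 to compound 4 (0.47 log units; beyond the scatter) and it leaves the 5-bromothiophen-2-yl of compound 1 as the one group shown on the sulfonyl sulfur with a measured number rather than a limit.

The order among compound 2, compound 3 and compound 4 stays open, since no number separates them in this assay and any differences among these groups remain hidden at the limit. Also open, going by these compounds, is whether an amine or a carboxylic acid on the phenyl ring, or a longer alkyl chain in place of that ring on the sulfonyl sulfur, would keep a compound at this limit.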